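Chloro to methyl swap in a weakly cytotoxic series

A few compounds are considered here, and "the series" means these few. Any claim that something is new, unique, unknown or untested is made for them only; others in the source may bear on it.

Measured compounds:
Compound 1 `OCc1cn(Cc2cccc(Cl)c2)c2ccccc12`: > 31600 nM
Compound 2 `Cc1cccc(Cn2cc(CO)c3ccccc32)c1`: > 31600 nM
Compound 3 `OCc1cn(Cc2ccc(Cl)cc2)c2ccc(F)cc12`: 8120 nM

In an ADME assay on T29 cells (Homo sapiens) for cytotoxicity, read by sulforhodamine B assay, with a stated time of 3 days (on this read-out higher numbers stand for weaker inhibition and lower numbers for stronger inhibition), compound 1 gives > 31600 nM, which is a limit of the assay and not a number. Compound 2 likewise gives > 31600 nM in this assay, again a limit. The change between them, (methyl in place of chloro on an aromatic carbon), is therefore a step that the two limits leave unreadable from compound 1 to compound 2; all that can be said of it is the limit of > 31600 nM in this assay, at which 2 of the 3 values shown sit. Compound 3 is the only one of the three with a number in this assay, where compound 3 gives 8120 nM. How the core of compound 3 differs from the core of compound 1 is not broken down here.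

Compound 4 `Cc1ccc(Cn2cc(CO)c3cc(F)ccc32)cc1` has not yet been measured. It differs from compound 3 by methyl in place of chloro on an aromatic carbon. For the measured compounds named here, this is the same kind of change as the one made from compound 1 to compound 2, not the same: there the group stood meta to a large group, here it stands para to a large group. The earlier step being a step that the two limits leave unreadable from compound 1 to compound 2, no size can be carried over from it, and the expectation rests on compound 3 alone. A step of a 1.5-fold higher number from compound 3 to compound 4 (0.17 log units; within the scatter) is expected, since the change swaps one heavy atom for another with no change in donors, acceptors or charge. Compound 4 is accordingly estimated at 12000 nM, between 4000 nM and 35000 nM, with a fair chance that this assay returns only a limit.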

Compound 4, half-maximal inhibitory concentration: 11700 nM
Compound 4: the middle estimate sits 1.0-fold (0.01 log units) above what was measured; the measured number falls inside the stated range.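

In this assay, methyl in place of chloro, para to a large group, gives a 1.4-fold higher number from compound 3 to compound 4 (0.16 log units; within the scatter), so on the core of compound 3 the swap leaves two compounds that this read-out does not tell apart. This is a single readable pair: it shows that the change can be made on that core without a step beyond the scatter, but it does not show that the change behaves alike on other cores or at another place on the ring, and the two pairs shown differ in both respects. The same swap on the core of compound 1 offers no support either way, as the step there cannot be read and the values stop at a limit of the assay, not a number: the limit of > 31600 nM in this assay, at which 2 of the 4 values shown sit.

The compounds shown leave open whether a group other than chloro or methyl at the same place, such as an amine, a carboxylic acid or a longer chain, would give a step beyond the scatter on the core of compound 3. Also open, as far as these compounds go, is whether the chloro to methyl swap stays within the scatter on any further core where both partners return numbers and not limits.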